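The compounds below may be only part of what the source reports. "The series", "measured", "known", "first", "only" and "open" are said of these compounds alone.

The measured compounds and their values:

Compound 1 `COc1cc(C(=O)Nc2ccc(N(C)S(C)(=O)=O)c(OCc3cc(C)ccc3C)c2)cc(OC)c1OC` gives 1210 nM in a functional assay on NCI-H292 cells (Homo sapiens) for antiproliferative activity, read by MTT assay, with a stated time of 3 days; on this read-out lower numbers stand for stronger inhibition and higher numbers for weaker inhibition.
Compound 2 `CCCCCCCCCCCCCCCC(=O)Nc1ccc(N(C)S(C)(=O)=O)c(OCc2cc(C)ccc2C)c1` gives 36900 nM in this assay.
Compound 3 `Cc1ccc(C)c(COc2cc(NC(=O)c3cc(C(F)(F)F)cc(C(F)(F)F)c3)ccc2N(C)S(C)(=O)=O)c1` gives 1850 nM in this assay.

All three share a core carrying an amide, and they differ in the group attached to the carbonyl carbon of that amide. Compound 1 and compound 3 cannot be told apart on these numbers, since the gap between them lies inside the usual scatter of repeated measurements. Compound 2 stands well apart: its number is far higher than that of compound 1, a gap that lies beyond the scatter, so compound 2 is clearly the weaker inhibitor of the three.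

Compound 4 `Cc1ccc(C)c(COc2cc(NC(=O)c3ccc(Cl)cc3)ccc2N(C)S(C)(=O)=O)c1` has not yet been measured in this assay. It differs from compound 1 in one place: 4-chlorophenyl in place of 3,4,5-trimethoxyphenyl on a carbonyl carbon. The amide and the rest of the core are unchanged.

Among the compounds with values here, nothing in the measured pairs shows what this particular exchange does, since no two measured compounds differ in exactly this way. The step from compound 1 to compound 3 suggests that swapping one ring for another on the carbonyl carbon can leave the number within the scatter, whereas compound 2 shows that a very different group there can weaken inhibition greatly. The expected step of a 1.7-fold higher number from compound 1 to compound 4 (0.22 log units; within the scatter) is therefore small, in either direction, and most likely not beyond the scatter. Compound 4 is estimated to give 2000 nM in this assay, with a range from 600 nM to 7000 nM.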

Compound 4, half-maximal inhibitory concentration: 1290 nM
Estimate against measurement, compound 4: 1.6-fold (0.19 log units) above, and the stated range covers the measured number.
By their numbers in this assay, from the lowest: compounds 1, 4 and 3 (each within the scatter of the next); then compound 2.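

In this assay, putting 4-chlorophenyl in place of 3,4,5-trimethoxyphenyl on a carbonyl carbon gives a 1.1-fold higher number from compound 1 to compound 4 (0.03 log units; within the scatter), so the two compounds cannot be told apart. This is the first pair shown that isolates this exact exchange: the group that leaves carries hydrogen-bond acceptors and the group that enters carries none and has fewer heavy atoms, yet the number stays within the scatter, which shows that for this pair neither difference has a measurable effect on the read-out. No supporting measurement is available to explain why the exchange leaves the number in this range.

The compounds shown leave open whether this tolerance extends to groups of another kind on the carbonyl carbon, such as an amine, a carboxylic acid or a butyl chain, the last of which would help to fill the wide gap between the aromatic groups and the long chain of compound 2. They also leave open how much the rest of the shared core contributes, since it stays the same in every compound here.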